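The source may hold more compounds than are shown below. What is called first, only, known or untested is meant among the compounds shown, and "the series" means these compounds.

In a functional assay on Raji cells (Homo sapiens) for cytotoxicity, with a stated time of 72 h (a higher number here means that more compound is needed for the effect, a lower number that less compound is needed), compound 1 `C=C[C@@](C)(/C=C/c1ccc(OC)cc1)CCC=C(C)C` gives > 26000 nM, which is a limit. Compound 2 `C=C[C@](C)(CCCC(C)C)CCc1ccc(O)cc1` gives > 26000 nM, also a limit. Compound 3 `C=C[C@@](C)(/C=C/c1ccc(O)cc1)CCC1OC1(C)C` gives > 22500 nM, again a limit, so it stands with the other two and the series holds no numerical value yet.

Compound 4 `C=C[C@@](C)(/C=C/c1ccc(O)cc1)CCCO` is next, with hydroxymethyl in place of 3,3-dimethyloxiran-2-yl on a saturated chain carbon, three bonds along the chain from two double-bonded chain carbons: hydroxymethyl in place of 3,3-dimethyloxiran-2-yl on a saturated chain carbon. Among the compounds with values here, no measured step is available as a guide, so nothing beyond the scatter is expected in this assay, in either direction. The expected change is a step that the limit leaves unreadable from compound 3 to compound 4. For compound 4 the estimated value is 28000 nM, with an expected range of 15000 nM to 45000 nM.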

Compound 4, half-maximal effective concentration: > 26000 nM
Compound 4: no number, only a limit; the forecaster's own chance of this, stated with the estimate: 85%; the middle value lies beyond the limit too.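

Within the data shown here, compound 3 and compound 4 both stand only as limits, so no step between them can be read. The compounds shown leave open whether any structure in this series gives a numerical value in this assay.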